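The source may hold more compounds than are shown below. What is called first, only, known or untested is meant among the compounds shown, and "the series" means these compounds.

For the measured compounds named here, in a functional assay on HeLa cells (Homo sapiens) for antiproliferative activity, read by resazurin assay (a higher number here means a weaker inhibitor, a lower number a stronger inhibitor), compound 2 `CCSC(=S)SCC(=O)c1ccc(OC)cc1` gives 2510 nM, the lowest of the three numbers measured so far. Compound 1 `CCSC(=S)SCC(=O)c1ccc(OC)c(OC)c1` gives 5010 nM, and compound 3 `COc1ccc(C(=O)CS)cc1` gives 20000 nM. Compound 4 `[C-]#[N+]c1ccc(C(=O)CSC(=S)SCC)cc1` has not yet been measured; it differs from compound 2 by a group of 2 heavy atoms (1 carbon, 1 nitrogen; no ring) in place of a group of 2 heavy atoms (1 carbon, 1 oxygen; no ring), on an aromatic carbon.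

Going by the values given here, two measured steps bear on this change. The step of a 2.0-fold lower number from compound 1 to compound 2 (0.30 log units; within the scatter) shows that taking a methoxy off the aromatic ring moved the number only within the scatter. The step of an 8.0-fold higher number from compound 2 to compound 3 (0.90 log units; beyond the scatter) shows that the part whose loss moved the number beyond the scatter was the group of 5 heavy atoms on the sulfur, and compound 4 keeps that group unchanged. Among the compounds with values here, since the step of a 2.0-fold lower number from compound 1 to compound 2 (0.30 log units; within the scatter) at the aromatic ring stayed within the scatter and compound 4 alters only that ring, the expected step of a 1.2-fold higher number from compound 2 to compound 4 (0.08 log units; within the scatter) is none beyond the scatter. Compound 4 is therefore estimated at 3000 nM, with a range from 1000 nM to 10000 nM.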

Compound 4, half-maximal inhibitory concentration: 7940 nM
Beside the measured number, compound 4's estimate is 2.6-fold (0.42 log units) below it, within the range that was stated.
By their numbers in this assay, from the lowest: compounds 2, 1 and 4 (each within the scatter of the next, the first and the last beyond it); then compound 3.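

In this assay, replacing the methoxy on this aromatic carbon gives a 3.2-fold higher number from compound 2 to compound 4 (0.50 log units; beyond the scatter). The earlier ring step, a 2.0-fold lower number from compound 1 to compound 2 (0.30 log units; within the scatter), removed a different methoxy, so this is the first step shown at this carbon, and it shows that the group here matters even though the group of 5 heavy atoms on the sulfur stays in place. Which difference between the two groups lies behind the step cannot be told, as nothing measured here addresses it.

On these data alone, a single replacement gives no trend for this carbon, so it remains open whether a hydrogen, a chlorine, an amine or a carboxylic acid here would stay close to compound 2 2510 nM. As far as these compounds go, it is also open whether the same replacement would give a similar step with the second methoxy of compound 1 kept on the ring.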